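Purine glycinamides in the tail flick test: arginine side chain

This account rests on a few compounds, and the source may have more. Where it says the series, first, only, none or still open, it means among the compounds named here.

Compound 1 `C[C@H](NC(=O)CN(c1nc(Cl)nc2[nH]cnc12)C1CC1)C(=O)O` gives 43.5% in a functional assay on the whole organism (Tail, strain ICR) with Mus musculus as the target, in the tail flick test, with a stated time of 90 min, at a dose of 25 umol/kg by the oral route; a lower number here means a weaker effect, a higher number a stronger effect of the compound at the dose given; compound 2 `CSCC[C@H](NC(=O)CN(c1nc(Cl)nc2[nH]cnc12)C1CC1)C(=O)O` gives 14%.

Compound 2 stands lowest of the two measured numbers, with compound 1 the nearest and higher. Compound 3 `N=C(N)NCCC[C@H](NC(=O)CN(c1nc(Cl)nc2[nH]cnc12)C1CC1)C(=O)O` carries a group of 5 heavy atoms (2 carbon, 3 nitrogen; no ring) in place of a group of 2 heavy atoms (1 carbon, 1 sulfur; no ring), on a saturated chain carbon, three bonds along the chain from an amide-type nitrogen and a carbonyl carbon. Among the compounds with values here, the only measured step, a number 29.5 percentage points lower from compound 1 to compound 2 (beyond the scatter), concerns a different change at the same chain and does not directly cover this exchange; it shows only that the side chain matters here. Within the data shown here, with no closer precedent, the step of a number 8 percentage points higher from compound 2 to compound 3 (within the scatter) is expected to stay near the scatter, in either direction. Compound 3 is therefore estimated at 22%, between 5% and 50%.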

Compound 3, a percentage reported as activity, at one dose (the size of the read-out at that dose, not a potency): 27.6%
Estimate against measurement, compound 3: 5.6 percentage points below; the range from low to high includes it.
By their numbers in this assay, from the lowest: compound 2; then compound 3; then compound 1.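

In this assay, the group of 5 heavy atoms in place of methylsulfanyl gives a number 13.6 percentage points higher from compound 2 to compound 3 (beyond the scatter), so the read-out at this chain carbon depends on which side chain is present, not only on whether one is present. Even so, this group does not match the hydrogen it replaces, with a number 15.9 percentage points lower from compound 1 to compound 3 (beyond the scatter), and both side chains shown stand lower than compound 1. No measurement here gives a reason for either step. The compounds leave open whether a simple amine or a carboxylic acid at the end of the chain would follow compound 3 or compound 2.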